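Adding Ethoxymethyl to the Aminomethyl-Hydroxyquinoline Core

The source may hold more compounds than are shown below. What is called first, only, known or untested is meant among the compounds shown, and "the series" means these compounds.

Measured compounds:
Compound 1, `CCN(CC)Cc1ccc2cccnc2c1O`: 13500 nM
Compound 2, `Oc1c(CN2CCCCC2)ccc2cccnc12`: 9770 nM

In a functional assay on A-431 cells (Homo sapiens) for inhibition, with a stated time of 72 h (on this read-out lower numbers stand for stronger inhibition and higher numbers for weaker inhibition), compound 1 gives 13500 nM and compound 2 gives 9770 nM. Among the measured compounds shown here, the single measured step, a 1.4-fold lower number from compound 1 to compound 2 (0.14 log units; within the scatter), shows that these two compounds cannot be told apart on this read-out; compound 2 stands among two numbers that lie within the scatter of each other.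

Compound 3, `CCOCc1cc(CN2CCCCC2)c(O)c2ncccc12`, differs from compound 2 by ethoxymethyl in place of hydrogen on an aromatic carbon. For the measured compounds named here, the only measured step concerns a change of the amine and does not touch the position where the ethoxymethyl enters, so no measured step bears on this change. There is no basis in the numbers shown for expecting a shift in one direction or the other beyond the scatter; the width of the expected range must therefore be broad.

Compound 3 is estimated at 8000 nM (range 2000 nM to 32000 nM). This expectation corresponds to a 1.2-fold lower number from compound 2 to compound 3 (0.09 log units; within the scatter).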

Compound 3, half-maximal inhibitory concentration: 23400 nM
Estimate against measurement, compound 3: 2.9-fold (0.47 log units) below, within the range that was stated.
By their numbers in this assay, from the lowest: compounds 2, 1 and 3 (each within the scatter of the next, the first and the last beyond it).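

In this assay, among the compounds shown here, ethoxymethyl in place of hydrogen gives a 2.4-fold higher number from compound 2 to compound 3 (0.38 log units; beyond the scatter) and so provides the first step here that lies beyond the scatter, although it is a modest one. The earlier pair differed only in the amine and could not be told apart, whereas this change on the aromatic carbon para to the hydroxy group and meta to the (piperidin-1-yl)methyl group moves the read-out toward weaker inhibition. No measurement given here accounts for this step.

The compounds shown leave open whether this shift is particular to ethoxymethyl or would also appear with another group on the same carbon, such as methyl, methoxymethyl, a longer ether chain, an aminomethyl group or a carboxylic acid. They also leave open whether ethoxymethyl would give a similar step with the diethylamino group of compound 1, as this single step stands only on the piperidin-1-yl pair.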